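Amine tail variation on the shared core: compound 3 to compound 4

A few compounds are considered here, and "the series" means these few. Any claim that something is new, unique, unknown or untested is made for them only; others in the source may bear on it.

Compound 1 `CC(C)N1CCC(Oc2ccc(-c3nc4ccc(Oc5ccc(Cl)cc5)cc4o3)cc2)CC1` gives 12.7% in an assay on isolated protein for inhibition of advanced glycosylation end product-specific receptor (Homo sapiens), read by FRET, with stated times of 30 min and 1 h, tested at 4 uM; on this read-out higher numbers stand for more inhibition at the one concentration tested (going by the name of the read-out) and lower numbers for less inhibition.
Compound 2 `Clc1ccc(Oc2ccc3nc(-c4ccc(OCCCN5CCCC5)cc4)oc3c2)cc1` gives "not active" (no number reported) in this assay.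
Compound 3 `N[C@H]1CCN(CCCOc2ccc(-c3nc4ccc(Oc5ccc(Cl)cc5)cc4o3)cc2)C1` gives 29.9% in this assay.

Compound 3 holds the highest of the two reported numbers; the nearest, compound 1, sits lower by a number 17.2 percentage points higher from compound 1 to compound 3 (beyond the scatter), and compound 2 is reported without a number. Among the measured compounds shown here, the only measured step exchanges the whole tail on the oxygen of the aromatic ring, a modest gain.

Compound 4 `Clc1ccc(Oc2ccc3nc(-c4ccc(OCCCN5CCNCC5)cc4)oc3c2)cc1` is not yet measured. It differs from compound 3 by piperazin-1-yl in place of 3-aminopyrrolidin-1-yl on a saturated chain carbon, three bonds along the chain from an oxygen on an aromatic ring. The two share the same atoms, joined differently: the amine leaves its position outside the five-membered ring and becomes part of a six-membered ring, while the chain to the oxygen stays. For the measured compounds named here, no measured step isolates such a ring rearrangement, so the bearing of a number 17.2 percentage points higher from compound 1 to compound 3 (beyond the scatter) is indirect: it only shows that the number in this assay is higher with the 3-(3-aminopyrrolidin-1-yl)propyl tail than with the 1-isopropylpiperidin-4-yl tail.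

Compound 4 is therefore expected to stay close to compound 3, with a small downward step a number 5.9 percentage points lower from compound 3 to compound 4 (within the scatter) that may lie within the scatter. The estimate for compound 4 in this assay is 24%, in the range 8% to 40%.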

Compound 4, a percentage reported as inhibition, at one concentration (the size of the read-out at that concentration, not a potency): 42.7%
Beside the measured number, compound 4's estimate is 18.7 percentage points below it, outside the stated range (above it).
By their numbers in this assay, from the lowest: compound 1; then compound 3; then compound 4.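

Working notes on the amine tail: in this assay this position, on a saturated chain carbon, three bonds along the chain from an oxygen on an aromatic ring, responds to how the same atoms are joined, with a number 12.8 percentage points higher from compound 3 to compound 4 (beyond the scatter) for piperazin-1-yl in place of 3-aminopyrrolidin-1-yl, although both groups have the same printed counts of heavy atoms, donors and acceptors. Exchanging the whole tail gives a number 30 percentage points higher from compound 1 to compound 4 (beyond the scatter) for 3-(piperazin-1-yl)propyl in place of 1-isopropylpiperidin-4-yl, so the earlier advantage of the propyl-linked tail in compound 3 is extended by a second propyl-linked amine, while compound 2, also propyl-linked, gives "not active" (no number reported) and shows that the chain alone does not ensure a number. No accompanying measurement explains these steps.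

Still open, as far as these compounds go, is whether the result follows the six-membered ring or its second ring nitrogen, a question that a morpholin-4-yl or 4-methylpiperazin-1-yl group on the same propyl chain would address. The compounds shown also leave open how the piperazin-1-yl group behaves on a shorter ethyl chain or a longer butyl chain, and how these single-concentration percentages relate to potency.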